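This account rests on a few compounds, and the source may have more. Where it says the series, first, only, none or still open, it means among the compounds named here.

Series notes. Compound 1 `CN1CCN(c2nc(-c3cccc(O)c3)nc3c2ncn3C)CC1` and compound 2 `Cn1cnc2c(N3CCCCC3)nc(-c3cccc(O)c3)nc21` share one core; compound 3 `Oc1ccc(-c2nc(N3CCCCC3)c3nc[nH]c3n2)cc1` and compound 4 `CN1CCN(c2nc(-c3ccc(O)cc3)nc3[nH]cnc23)CC1` share another, and the difference between the two cores is not broken down here. In an assay on cells for displacement of a labelled ligand from adenosine receptor A2b (Homo sapiens), read by scintillation counting and radioligand binding, with a stated time of 30 min, tested at 10 uM (a lower number here means less inhibition, a higher number more inhibition at the concentration tested (going by the name of the read-out)), compound 2 gives 29.3%. In this assay compound 1 gives 47.8%. The step of a number 18.5 percentage points higher from compound 2 to compound 1 (beyond the scatter) accompanies the change (4-methylpiperazin-1-yl in place of piperidin-1-yl on an aromatic carbon). For compound 3 the read-out in this assay is the limit > 80% and not a number, as noted in the limit of > 80% in this assay, at which 1 of the 3 values shown sits. The change to compound 4 is 4-methylpiperazin-1-yl in place of piperidin-1-yl on an aromatic carbon, the same kind of change as before; the place differs only in being meta to a 4-hydroxyphenyl group rather than meta to a 3-hydroxyphenyl group. For compound 4 a step that the limit leaves unreadable from compound 3 to compound 4 is expected, resting on the earlier step of a number 18.5 percentage points higher from compound 2 to compound 1 (beyond the scatter). Compound 4 is therefore estimated at 85% in this assay, with a range from 65% to 98%.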

Compound 4, a percentage reported as inhibition, at one concentration (the size of the read-out at that concentration, not a potency): 53%
For compound 4 the middle estimate is 32 percentage points above the measured one; measured number below the stated range.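

In this assay, 4-methylpiperazin-1-yl in place of piperidin-1-yl gives a number at least 27 percentage points lower from compound 3 to compound 4 (beyond the scatter), so the change does not carry over from the core of compound 1 to the core of compound 3 with the same direction: the same change on two cores in this assay, a number 18.5 percentage points higher (beyond the scatter) from compound 2 to compound 1 and a number at least 27 percentage points lower (beyond the scatter) from compound 3 to compound 4, at least 45.5 percentage points apart, beyond the scatter of two such steps

For compound 3 the read-out > 80% is a limit and not a number: the limit of > 80% in this assay, at which 1 of the 4 values shown sits.

These two pairs do not show which difference goes with the opposite directions, the 4-hydroxyphenyl group against the 3-hydroxyphenyl group or another part of the cores.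

Open, going by these compounds, is whether a morpholin-4-yl or an unsubstituted piperazin-1-yl group at this place follows either pair. Also open, on these data alone, is how the same change reads with a 3-hydroxyphenyl group on the core of compound 3.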